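A few compounds are considered here, and "the series" means these few. Any claim that something is new, unique, unknown or untested is made for them only; others in the source may bear on it.

Measured in a functional assay on MDA-MB-231 cells (Homo sapiens) for cytotoxicity, read by MTT assay, with a stated time of 48 h; on this read-out higher numbers stand for weaker inhibition and lower numbers for stronger inhibition:
- compound 1 `CCCCCCCC(=O)NCC(=O)N[C@@H](C)C(=O)N[C@@H](CC(C)C)C(=O)N[C@](C)(CC)C(=O)N[C@@H](CO)C(=O)N[C@H](C(=O)N[C@H](CO)CC(C)C)[C@@H](C)CC`: 4000 nM
- compound 2 `CCCCCCCC(=O)NCC(=O)N[C@@H](C)C(=O)N[C@@H](CC(C)C)C(=O)NC(C)(C)C(=O)N[C@@H](C)C(=O)N[C@H](C(=O)N[C@H](CO)CC(C)C)[C@@H](C)CC`: 16000 nM

Compound 2, at 16000 nM, has the higher of the two numbers and so the weaker inhibition, compared with compound 1 at 4000 nM. This gap lies beyond the scatter.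

The next compound is compound 3 `CCCCCCCC(=O)NCC(=O)N[C@@H](C)C(=O)N[C@@H](CC(C)C)C(=O)N[C@](C)(CC)C(=O)N[C@@H](C)C(=O)N[C@H](C(=O)N[C@H](CO)CC(C)C)[C@@H](C)CC`. Its change from compound 2 is methyl in place of hydrogen on a saturated chain carbon, two bonds along the chain from an amide-type nitrogen and a carbonyl carbon.

Among the compounds with values here, the series offers no measured step between compounds that differ in one place, so this change has no direct precedent. A small move toward lower numbers is expected in this assay, most likely not beyond the scatter. Within the data shown here, the only guide is the span of the two values, and compound 1 at 4000 nM is taken as a rough lower reference.

The estimated change is a 1.6-fold lower number from compound 2 to compound 3 (0.20 log units; within the scatter).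

For compound 3 the expected value is 10000 nM, with an estimated range of 4000 nM to 20000 nM.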

Compound 3, half-maximal inhibitory concentration: 5000 nM
Compound 3: middle estimate off by 2.0-fold (0.30 log units), on the high side; the range from low to high includes it.
By their numbers in this assay, from the lowest: compounds 1 and 3 (each within the scatter of the next); then compound 2.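

In this assay, methyl in place of hydrogen on a saturated chain carbon, two bonds along the chain from an amide-type nitrogen and a carbonyl carbon, gives a 3.2-fold lower number from compound 2 to compound 3 (0.51 log units; beyond the scatter); this first single-place step in the series shows that one added carbon at this position can move the number beyond the scatter. A second single-place change, hydrogen in place of hydroxy on a saturated chain carbon, two bonds along the chain from an amide-type nitrogen and a carbonyl carbon, gives a 1.3-fold higher number from compound 1 to compound 3 (0.10 log units; within the scatter), so this read-out does not separate hydroxy from hydrogen at that position. Nothing available accounts for either step.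

On these data alone, it remains open whether a longer chain, such as propyl or butyl, at the position of the methyl change would extend the move toward lower numbers, hold it, or reverse it. As far as these compounds go, it is equally open whether an amine or a carboxylic acid at the position of the hydroxy change would stay within the scatter of hydroxy and hydrogen.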